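Aryl piperazine changes on a shared amide core

The source may report more compounds than this note shows. Statements on the series, on what has been measured and on what is new or still open speak of the compounds shown alone.

Measured so far in a functional assay on MDA-MB-231 cells (Homo sapiens) for inhibition, read by sulforhodamine B assay, with a stated time of 48 h; on this read-out higher numbers stand for weaker inhibition of growth and lower numbers for stronger inhibition of growth:
compound 1 `O=C(CCN1C(=O)CSc2ccccc21)N1CCN(c2ccc(C(F)(F)F)cc2)CC1` gives 1000 nM.
compound 2 `O=C(CCN1C(=O)CSc2ccccc21)N1CCN(c2ccccc2)CC1` gives 5400 nM.
compound 3 `O=C(CCN1C(=O)CSc2ccccc21)NCCCN1CCN(c2ccc([N+](=O)[O-])cc2)CC1` gives > 100000 nM, which is a limit of the assay and not a number.

Compound 3 therefore stands at the limit of > 100000 nM in this assay, at which 1 of the 3 values shown sits, and no number is known for it. Compound 4 `COc1ccccc1N1CCN(CCCNC(=O)CCN2C(=O)CSc3ccccc32)CC1` differs from compound 3 by 2-methoxyphenyl in place of 4-nitrophenyl on an amine nitrogen in a ring. Among the compounds with values here, the only measured step, a 5.4-fold higher number from compound 1 to compound 2 (0.73 log units; beyond the scatter), also alters the substituent on the aryl ring of the shared core, but on the shorter linker and with a different pair of groups, and it is modest in size. With compound 3 at the limit, a step of that size in either direction could still leave compound 4 without a measured number. Compound 4 is expected to stay weak, at 60000 nM with a range of 15000 nM to 200000 nM. This estimate means an at least 1.6-fold lower number from compound 3 to compound 4 (0.22 log units; that floor lies within the scatter).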

Compound 4, concentration for 50% growth inhibition: 2000 nM
The estimate for compound 4 lay 30-fold (1.48 log units) above the measured number; measured number outside the range, below it.
By their numbers in this assay, from the lowest: compounds 1 and 4 (each within the scatter of the next); then compound 2. At a limit, above all of these: compound 3.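

In this assay the change on the amine nitrogen in the ring gives an at least 50-fold lower number from compound 3 to compound 4 (1.69 log units; beyond the scatter) and so the aryl group at this position can move growth inhibition by a large step on the longer linker. Going by these compounds, compound 3 stands at a limit of the assay and not at a number, so the true size of this step stays unknown: the limit of > 100000 nM in this assay, at which 1 of the 4 values shown sits.

On these data alone, whether the substituent itself or its place on the aryl ring carries the step stays open. A 4-methoxyphenyl or a 2-nitrophenyl group on the same linker would separate the two.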